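Bromo for Chloro: Expected Cytotoxicity of Compound 3

The source may report more compounds than this note shows. Statements on the series, on what has been measured and on what is new or still open speak of the compounds shown alone.

Measured so far:
Compound 1, `COc1cccc(-c2cc(-c3ccc(C4NC(=O)c5ccccc5N4)cc3)nc(N)n2)c1OC`, gives > 400000 nM in an ADME assay on J774.A1 cells (Mus musculus) for cytotoxicity, read by MTT assay, with a stated time of 72 h; on this read-out lower numbers stand for higher toxicity in this test and higher numbers for lower toxicity in this test.
Compound 2, `Nc1nc(-c2ccc(Cl)cc2)cc(-c2ccc(C3NC(=O)c4ccccc4N3)cc2)n1`, gives 82200 nM in this assay.

In this assay, within the data shown here, compound 2 stands as the only plain number among the two values shown. Compound 1 reaches only the limit of the assay, > 400000 nM, so its true value is not known. Among the measured compounds shown here, the single measured step, an at least 4.8-fold lower number from compound 1 to compound 2 (0.68 log units; beyond the scatter), replaces one aryl group by another and gives the only hint of how this shared core responds to change; that it rests on a limit is recorded in the limit of > 400000 nM in this assay, at which 1 of the 2 values shown sits.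

Compound 3, `Nc1nc(-c2ccc(Br)cc2)cc(-c2ccc(C3NC(=O)c4ccccc4N3)cc2)n1`, differs from compound 2 by bromo in place of chloro on an aromatic carbon. For the measured compounds named here, no measured step swaps one halogen for another, so the aryl swap from compound 1 to compound 2 bears on this change only loosely. Exchanging chloro for bromo is a small alteration, and the expectation is a step of a 1.0-fold lower number from compound 2 to compound 3 (0.01 log units; within the scatter), within the scatter. Compound 3 is therefore estimated at 80000 nM, with a range from 35000 nM to 200000 nM.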

Compound 3, half-maximal cytotoxic concentration: 125000 nM
For compound 3 the middle estimate is 1.6-fold (0.19 log units) below the measured one; the range from low to high includes it.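

Until now this position had been seen only through the exchange of a whole aryl group. Here one halogen alone changes, and in this assay the result is a 1.5-fold higher number from compound 2 to compound 3 (0.18 log units; within the scatter), so this test does not separate the 4-chlorophenyl compound from the 4-bromophenyl compound. The larger exchange, from 2,3-dimethoxyphenyl to 4-bromophenyl, gives an at least 3.2-fold lower number from compound 1 to compound 3 (0.50 log units; beyond the scatter), which points the same way as an at least 4.8-fold lower number from compound 1 to compound 2 (0.68 log units; beyond the scatter), so both halogen-bearing compounds read as more toxic in this test than compound 1, though how much more remains uncertain: the limit of > 400000 nM in this assay, at which 1 of the 3 values shown sits.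

The compounds shown leave open whether a group of another kind in place of the halogen, such as an amine or a carboxylic acid, would move the number beyond the scatter. They also leave open what a plain phenyl ring without any halogen would give, and whether a single methoxy group at this place would be enough to bring the number close to that of compound 1, whose > 400000 nM is a limit and not a number.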